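The source may hold more compounds than are shown below. What is called first, only, known or untested is meant among the compounds shown, and "the series" means these compounds.

In a functional assay on A549 cells (Homo sapiens) for antiproliferative activity, read by CCK-8 assay, with a stated time of 72 h (on this read-out lower numbers stand for stronger inhibition and higher numbers for weaker inhibition), compound 1 `CC1=NN(c2ccccc2)C(=O)C12C=CC(=O)C=C2c1ccccc1` gives 16500 nM. Compound 2 `CC1=NN(c2cccc(Cl)c2)C(=O)C12C=CC(=O)C=C2c1ccccc1` gives 18800 nM in this assay, which is the highest of the two plain numbers shown, with compound 1 nearest; the step of a 1.1-fold higher number from compound 1 to compound 2 (0.06 log units; within the scatter) stays within the scatter. Compound 3 `CC1=NN(c2ccc(Cl)cc2)C(=O)C12C=CC(=O)C=C2c1ccccc1` reaches only a limit of the assay in this assay, > 100000 nM. Compound 3 sits at the limit of > 100000 nM in this assay, at which 1 of the 3 values shown sits. The steps of an at least 6.0-fold higher number from compound 1 to compound 3 (0.78 log units; beyond the scatter) and an at least 5.3-fold higher number from compound 2 to compound 3 (0.72 log units; beyond the scatter) are both beyond the scatter.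

Compound 4 `CC1=NN(c2cccc(Cl)c2)C(=O)C12C=CC(=O)C=C2c1ccc(C)cc1` differs from compound 2 by methyl in place of hydrogen on an aromatic carbon, a methyl in place of hydrogen on an aromatic carbon, para to a large group, so that phenyl becomes 4-methylphenyl. None of the three measured steps touches this ring: each concerns chloro on the ring at the amide-type nitrogen, and the chloro steps give no guide for a methyl on the other phenyl. Among the compounds with values here, with no bearing step, the expected change in this assay is a 1.1-fold higher number from compound 2 to compound 4 (0.03 log units; within the scatter), not beyond the scatter. Compound 4 is therefore estimated at 20000 nM in this assay, with a range from 8000 nM to 60000 nM.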

Compound 4, half-maximal inhibitory concentration: 9050 nM
Beside the measured number, compound 4's estimate is 2.2-fold (0.34 log units) above it; low and high end bracket the measured number.
By their numbers in this assay, from the lowest: compounds 4, 1 and 2 (each within the scatter of the next, the first and the last beyond it). At a limit, above all of these: compound 3.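

In this assay, methyl in place of hydrogen on this phenyl gives a 2.1-fold lower number from compound 2 to compound 4 (0.32 log units; beyond the scatter), a modest change beyond the scatter. This is the first change shown on the phenyl that does not sit on the amide-type nitrogen, so the earlier chloro steps, all on the ring at that nitrogen, could not reveal that this second ring also responds to substitution. None of the available data bears on why the number falls with this methyl.

Going by these compounds, the step rests on a single pair with the 3-chlorophenyl group in place, so it remains open whether 4-methylphenyl would shift the number likewise with the unsubstituted phenyl of compound 1. On these data alone, it is also open how a longer chain such as ethyl, a methoxy group, an amine or a carboxylic acid would read at this same place.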